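The source may report more compounds than this note shows. Statements on the series, on what has been measured and on what is new or still open speak of the compounds shown alone.

Working notes on the series. Of the compounds shown here, two have been measured in a functional assay on CHO cells for antagonist activity at sphingosine 1-phosphate receptor 2 (Homo sapiens), read by scintillation counting and GTPgammaS binding, with a stated time of 4 h, in the presence of a further agent that is not named here; a lower number here means a stronger inhibitor, a higher number a weaker inhibitor. Compound 1 `CCOC(=O)c1cc(C)cc(NNC(=O)Nc2cc(Cl)nc(Cl)c2)n1` gives 2.1 nM in this assay. Compound 2 `Cc1cc(NNC(=O)Nc2cc(Cl)nc(Cl)c2)ncc1-c1cnn(C)c1` gives 3.4 nM in this assay. Compound 2 and compound 1 lie within the scatter of each other; neither is set apart on the numbers in hand.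

Among the compounds with values here, no step between measured compounds that differ in one place exists in this set, so the next step is unanchored. Compound 3 `Cc1cc(NNC(=O)Nc2cc(Cl)nc(Cl)c2)ncc1-c1cn(C)nc1C` is not yet measured in this assay. It differs from compound 2 in one place: methyl in place of hydrogen on an aromatic carbon, the difference read one bond further out being 1-methyl-1H-pyrazol-4-yl to 1,3-dimethyl-1H-pyrazol-4-yl.

Within the data shown here, with no comparable step on record, the expected step from compound 2 to compound 3, a 1.2-fold higher number from compound 2 to compound 3 (0.07 log units; within the scatter), is small, with no direction asserted beyond the scatter. Compound 3 is estimated at 4 nM in this assay, with a range from 1.5 nM to 12 nM.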

Compound 3, half-maximal inhibitory concentration: 0.8 nM
Compound 3: middle estimate off by 5.0-fold (0.70 log units), on the high side; the whole stated range lies above it.
By their numbers in this assay, from the lowest: compound 3; then compounds 1 and 2 (each within the scatter of the next).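

In this assay the change from 1-methyl-1H-pyrazol-4-yl to 1,3-dimethyl-1H-pyrazol-4-yl gives a 4.3-fold lower number from compound 2 to compound 3 (0.63 log units; beyond the scatter) and shows that this carbon of the five-membered aromatic ring, next to the ring nitrogen and next to the ring atom that bears a large group, accepts a methyl group with a modest gain in inhibition. Within the data shown here, this is the first step between compounds that differ in one place, and it shows that the read-out responds to a single added carbon at this position. No measurement at hand accounts for the size or direction of this step.

As far as these compounds go, whether an ethyl group, a longer chain or an amine on the same carbon would move the number in the same direction as methyl remains open. Also open, from the compounds shown here alone, is whether the gain from methyl would hold with other groups on the shared core.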